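The source may hold more compounds than are shown below. What is called first, only, known or untested is meant among the compounds shown, and "the series" means these compounds.

Measured so far:
compound 1 `NCCCCN(C[C@@H]1Cc2nccnc2CN1)[C@H]1CCCc2cccnc21` — 2 nm/s
compound 2 `CN(C[C@@H]1Cc2ncccc2CN1)[C@H]1CCCc2cccnc21` — 230 nm/s
compound 3 `NC/C=C\CN(C[C@H]1Cc2ncccc2CN1)[C@H]1CCCc2cccnc21` — 28 nm/s

In an ADME assay for permeability, using PAMPA, with a stated time of 4 h, at pH 5.5 (on this read-out higher numbers stand for higher permeability and lower numbers for lower permeability), compound 3 sits second of the three numbers. Compound 2 stands higher by a margin beyond the scatter, and compound 1 lower by a margin also beyond the scatter. Compound 4 `c1cnc2c(c1)CN[C@@H](CN(CCCCNC1CCOCC1)[C@H]1CCCc3cccnc31)C2` is not yet measured; against compound 3 the change is 3-((oxan-4-yl)amino)propyl in place of 3-aminoprop-1-en-1-yl on a saturated chain carbon bound to an amine nitrogen. Among the measured compounds shown here, no step between measured compounds shares this change, so the direction is open. Compound 1, which also carries a chain ending in an amine, gives 2 nm/s, while compound 2 with only a methyl gives 230 nm/s. For compound 4 a modest upward step is expected, a 1.6-fold higher number from compound 3 to compound 4 (0.21 log units; within the scatter), within wide bounds. The value for compound 4 is estimated at 45 nm/s, from 8 nm/s to 200 nm/s.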

Compound 4, apparent permeability: 2 nm/s
Compound 4: the middle estimate sits 23-fold (1.35 log units) above what was measured; the measured number lies below the stated range.
By their numbers in this assay, from the lowest: compounds 1 and 4 (each within the scatter of the next); then compound 3; then compound 2.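

The first step readable at this place, on a saturated chain carbon bound to an amine nitrogen, shows that this assay responds strongly to the group there, with a 14-fold lower number from compound 3 to compound 4 (1.15 log units; beyond the scatter). The oxan-4-yl ring, the larger group and the loss of the chain double bond all arrive together in this single step, so it cannot assign the drop to any one of them. Nothing at hand accounts for the size of the step. Open, on these data alone, is what a 3-hydroxypropyl group would give at this place, with no amine in the chain.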